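The source may report more compounds than this note shows. Statements on the series, on what has been measured and on what is new or still open speak of the compounds shown alone.

Measured in a functional assay on MCF7 cells (Homo sapiens) for cytotoxicity, read by MTT assay, with a stated time of 48 h; on this read-out lower numbers stand for stronger inhibition and higher numbers for weaker inhibition:
- Compound 1 `CCOC(=O)C1=C(C)NC(=S)NC1c1cccc(OCCCCOc2cccc(C3NC(=S)NC(C)=C3C(=O)OCC)c2)c1`: 186 ug/mL
- Compound 2 `COC(=O)[C@@H]1CCCN1C(=O)C1=C(C)NC(=S)NC1c1cccc(OC/C=C/COc2cccc(C3NC(=S)NC(C)=C3C(=O)N3CCC[C@H]3C(=O)OC)c2)c1`: 54 ug/mL
- Compound 3 `COC(=O)[C@@H]1CCCN1C(=O)C1=C(C)NC(=S)NC1c1ccc(OC/C=C\COc2ccc(C3NC(=S)NC(C)=C3C(=O)N3CCC[C@H]3C(=O)OC)cc2OC)c(OC)c1`: 175 ug/mL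

Compound 3, at 175 ug/mL, is the second highest of these three numbers. It lies within the usual scatter of compound 1, so those two cannot be told apart in this assay. Compound 2 gives a clearly lower number than compound 3, with a gap beyond the scatter.

The next compound to be tested is compound 4 `COC(=O)[C@@H]1CCCN1C(=O)C1=C(C)NC(=S)NC1c1ccc(OC/C=C/COc2ccc(C3NC(=S)NC(C)=C3C(=O)N3CCC[C@H]3C(=O)OC)cc2OC)c(OC)c1`. It has the same atoms and bonds as compound 3: the two compounds have the same atoms and bonds; at least one stereo element is drawn with a configuration in one of them and without one in the other: 1 of 5 stereo elements differ; a double bond is drawn Z in compound 3 and E in compound 4. Thus a double bond is drawn Z in compound 3 and E in compound 4.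

Within the data shown here, no measured pair isolates this change. The nearest hint is compound 2, also drawn E at its double bond, which gives 54 ug/mL, but it differs from compound 4 elsewhere as well. That hint supports only a cautious lean toward a lower number in this assay, and the step is expected to stay small, probably within the scatter. The estimated change is a 1.5-fold lower number from compound 3 to compound 4 (0.16 log units; within the scatter). The estimate for compound 4 is 120 ug/mL, with an expected range from 55 ug/mL to 250 ug/mL.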

Compound 4, half-maximal inhibitory concentration: 60 ug/mL
The estimate for compound 4 lay 2.0-fold (0.30 log units) above the measured number; measured number inside the range.
By their numbers in this assay, from the lowest: compounds 2 and 4 (each within the scatter of the next); then compounds 3 and 1 (each within the scatter of the next).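

Among these compounds, until this point, no two compounds differed in a single place, so nothing could be read about any one change. Compounds 3 and 4 supply that first clean pair: in this assay, the step is a 2.9-fold lower number from compound 3 to compound 4 (0.46 log units; beyond the scatter), and it lies beyond the scatter although no atom or bond enters or leaves, which shows that the way the double bond in the linking chain is drawn can by itself go with a readable difference in this series. The reading remains modest, and it rests on one pair with a caution about how the two structures are drawn: the fact that one of compounds 3 and 4 is drawn with a defined configuration and the other without, at the place where they differ

On these data alone, whether the same step appears outside this one pair stays open, as the methoxy-bearing compounds 3 and 4 are the only two that share everything but the double bond, and compound 2 has no partner of the opposite geometry. Also open, as far as these compounds go, is how the number would respond to a free carboxylic acid in place of the methyl ester, or to a longer linking chain while the double bond is kept.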